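Acetyl on the thiazole ring of compound 2

The source may report more compounds than this note shows. Statements on the series, on what has been measured and on what is new or still open speak of the compounds shown alone.

The shared core of compound 2 `CC(=O)N(c1nc(C)cs1)N(C(C)=O)S(=O)(=O)c1ccc(C)cc1` carries a methyl group on its five-membered ring, and in a functional assay on HepG2 cells (Homo sapiens) for inhibition, read by XTT assay, with a stated time of 72 h (on this read-out higher numbers stand for weaker inhibition and lower numbers for stronger inhibition), compound 2 gives 7360 nM. Among the three values shown, compound 2 stands as the only measured number. For compound 1 `Cc1ccc(S(=O)(=O)NNc2nc(C)cs2)cc1` this assay reports only a limit, < 5650 nM (the limit of < 5650 nM in this assay, at which 1 of the 3 values shown sits). For compound 3 `CC(=O)N(c1nc(-c2ccccc2)cs1)N(C(C)=O)S(=O)(=O)c1ccc(C)cc1` this assay likewise reports only a limit, > 58200 nM (the limit of > 58200 nM in this assay, at which 1 of the 3 values shown sits). For the measured compounds named here, the one measured step, an at least 7.9-fold higher number from compound 2 to compound 3 (0.89 log units; beyond the scatter), runs in the direction of weaker inhibition. Compound 4 `CC(=O)c1sc(N(C(C)=O)N(C(C)=O)S(=O)(=O)c2ccc(C)cc2)nc1C` differs from compound 2 by acetyl in place of hydrogen on an aromatic carbon. Going by the values given here, no measured step places an acetyl group at that carbon; the step from compound 2 to compound 3 concerns a different ring carbon and a larger group, so it bears only loosely on the change. The account therefore expects for compound 4 a small step, a 1.6-fold higher number from compound 2 to compound 4 (0.21 log units; within the scatter), and estimates for compound 4 a value of 12000 nM, within 3500 nM to 45000 nM.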

Compound 4, half-maximal inhibitory concentration: 57400 nM
The estimate for compound 4 lay 4.8-fold (0.68 log units) below the measured number; the whole stated range lies below it.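

For the compounds shown here, with compound 4, the ring carbon next to the ring sulfur enters the account for the first time: in this assay, acetyl in place of hydrogen there gives a 7.8-fold higher number from compound 2 to compound 4 (0.89 log units; beyond the scatter), so this carbon does not tolerate the change without a measurable shift towards weaker inhibition. Going by these compounds alone, the only earlier step from compound 2 concerned the ring atom that bears a methyl group and rested on a limit, whereas this step joins two measured numbers. The compounds shown give no cause for the shift.

It remains open whether any group at this carbon weakens inhibition or whether the effect is specific to acetyl, since an amine, a carboxylic acid or a chlorine atom there is not among the compounds shown. As far as these compounds go, the same change on the core of compound 1 also remains open.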